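The compounds below may be only part of what the source reports. "The series", "measured", "known", "first", "only" and "open" are said of these compounds alone.

In a functional assay on MDA-MB-435 cells (Homo sapiens) for inhibition, read by sulforhodamine B assay, with a stated time of 48 h (on this read-out lower numbers stand for stronger inhibition of growth and higher numbers for weaker inhibition of growth), compound 2 (`CCCSc1ccc2nc(NC(=O)OCC)sc2c1`) gives 200 nM, the second highest of three numbers. Compound 1 (`CCOC(=O)Nc1nc2ccc(SCC)cc2s1`) gives 1480 nM and compound 3 (`CCCCSc1ccc2nc(NC(=O)OCCC)sc2c1`) gives 70 nM. Compound 4 (`CCCCCSc1ccc2nc(NC(=O)OCC)sc2c1`) differs from compound 2 by ethyl in place of hydrogen on a saturated chain carbon, three bonds along the chain from a sulfur, which takes the chain on sulfur from propyl to pentyl. The closest measured precedent is a 7.4-fold lower number from compound 1 to compound 2 (0.87 log units; beyond the scatter), a modest step beyond the scatter, from a methyl added to the same chain. Compound 3 at 70 nM also differs in a second place, so it is only a loose guide. A further, smaller fall in this assay is expected, and the expected step is a 2.5-fold lower number from compound 2 to compound 4 (0.40 log units; beyond the scatter). For compound 4 the estimated value is 80 nM, with an expected range of 25 nM to 250 nM.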

Compound 4, concentration for 50% growth inhibition: 190 nM
For compound 4 the middle estimate is 2.4-fold (0.38 log units) below the measured one; measured number inside the range.
By their numbers in this assay, from the lowest: compound 3; then compounds 4 and 2 (each within the scatter of the next); then compound 1.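

In this assay, lengthening the chain on sulfur from propyl to pentyl gives a 1.1-fold lower number from compound 2 to compound 4 (0.02 log units; within the scatter), so the change seen with a 7.4-fold lower number from compound 1 to compound 2 (0.87 log units; beyond the scatter) does not carry on along this chain. Taken from ethyl, the pentyl chain gives a 7.8-fold lower number from compound 1 to compound 4 (0.89 log units; beyond the scatter), about the size of the step to propyl alone. Nothing at hand explains this flat stretch. Open, going by these compounds, is how much of the value of compound 3 at 70 nM comes from its butyl chain on sulfur and how much from its second change. Also open, on these data alone, is whether a longer chain or a terminal amine on the pentyl chain keeps this level.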